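This account rests on a few compounds, and the source may have more. Where it says the series, first, only, none or still open, it means among the compounds named here.

In an assay (Rattus norvegicus) for inhibition of Fatty-acid amide hydrolase 1 (Homo sapiens) (a lower number here means a stronger inhibitor, a higher number a weaker inhibitor), compound 3 `NC(=O)c1ccc(-c2cnc(C(=O)CCCCCCc3ccccc3)o2)nc1` gives 1.2 nM, the lowest of the three numbers measured. The other two are compound 1 `Nc1ccc(-c2cnc(C(=O)CCCCCCc3ccccc3)o2)cc1` with 90 nM and compound 2 `Cc1cccnc1-c1cnc(C(=O)CCCCCCc2ccccc2)o1` with 15 nM. Every measured step swaps one six-membered aromatic group for another at the same carbon of the shared core: a 6.0-fold lower number from compound 1 to compound 2 (0.78 log units; beyond the scatter), a 13-fold lower number from compound 2 to compound 3 (1.10 log units; beyond the scatter) and a 75-fold lower number from compound 1 to compound 3 (1.88 log units; beyond the scatter). Compound 4 `O=C(CCCCCCc1ccccc1)c1ncc(F)o1` takes a different kind of step, (fluoro in place of 5-carbamoylpyridin-2-yl on an aromatic carbon). Among the measured compounds shown here, no measured step removes the aromatic group altogether, so the three steps set only a loose frame: each shows that what sits at this carbon moves the number a great deal, and compound 3 carries the group that gave the lowest number. Losing that group is therefore expected to raise the number, and by a large step, a 420-fold higher number from compound 3 to compound 4 (2.62 log units; beyond the scatter), though with wide uncertainty because nothing measured here resembles fluoro at that position. For compound 4 the expected value is 500 nM, within 80 nM to 3000 nM.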

Compound 4, inhibition constant: 30 nM
Beside the measured number, compound 4's estimate is 17-fold (1.22 log units) above it, outside the stated range (below it).
By their numbers in this assay, from the lowest: compound 3; then compounds 2 and 4 (each within the scatter of the next); then compound 1.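

In this assay, a single fluoro atom with no ring at this carbon still leaves a fairly strong inhibitor, so an aromatic ring here is not needed for a number in this range. What the ring can add depends on which ring it is: 5-carbamoylpyridin-2-yl is clearly better than fluoro, as a 25-fold higher number from compound 3 to compound 4 (1.40 log units; beyond the scatter) shows, while 3-methylpyridin-2-yl cannot be told apart from it, with a 2.0-fold higher number from compound 2 to compound 4 (0.30 log units; within the scatter). The 4-aminophenyl group is actually worse than this one atom, with a 3.0-fold lower number from compound 1 to compound 4 (0.48 log units; beyond the scatter), so replacing a large group with a small one can lower the number as well as raise it.

No measurement offered here explains these differences. From the compounds shown here alone, it remains open whether the carbamoyl group or the pyridine ring accounts for the low number of compound 3, and how a plain hydrogen, a chlorine or a carboxylic acid at this carbon would compare with fluoro.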